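The compounds below may be only part of what the source reports. "The series", "measured", "known", "first", "only" and "open" are said of these compounds alone.

Measured compounds:
Compound 1 `CC1=CC[C@H](C(C)(C)N=C=S)CC1`: in a functional assay on K562 cells (Homo sapiens) for inhibition, read by sulforhodamine B assay, with a stated time of 48 h (on this read-out higher numbers stand for weaker inhibition of growth and lower numbers for stronger inhibition of growth), compound 1 gives > 100000 nM, which is a limit of the assay and not a number.
Compound 2 `CC1=CC[C@H](C(C)(C)NC(=S)N/N=C/c2ccc(O)cc2)CC1`: in this assay compound 2 gives > 100000 nM, likewise a limit of the assay.

Compound 2 thus stands at the boundary of what the measurement reports, and so does compound 1; the two values show no difference between them, both sitting at the limit of > 100000 nM in this assay, at which 2 of the 2 values shown sit. Compound 3 `CC1=CC[C@H](C(C)(C)NC(=S)N/N=C/c2ccc(F)cc2)CC1` differs from compound 2 by fluoro in place of hydroxy on an aromatic carbon, in words fluoro in place of hydroxy on an aromatic carbon. Within the data shown here, no step between measured compounds is known here, so the size of this change in this assay cannot be read from any measured pair. The step that the estimate means, a number no higher from compound 2 to compound 3 (the limit leaves the size open), is expected to be none beyond the scatter. This expectation rests on compound 2, whose value in this assay is the limit > 100000 nM. Compound 3 is therefore estimated to give 100000 nM in this assay, within a range from 30000 nM to 300000 nM, and most likely again only a limit rather than a number.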

Compound 3, concentration for total growth inhibition: > 100000 nM
Compound 3 was reported as a limit (the forecaster's own chance of this, stated with the estimate: 80%); the middle value lies on the limit itself.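

In this assay compound 3 gives > 100000 nM as a limit of the assay and not a number. Compound 2 also stands at a limit, so no step can be read from compound 2 to compound 3: the limit of > 100000 nM in this assay, at which 3 of the 3 values shown sit. The compounds shown leave open whether fluoro in place of hydroxy alters growth inhibition at all.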